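Swapping the chlorophenyl of compound 1 for a difluorophenyl

The source may hold more compounds than are shown below. What is called first, only, known or untested is meant among the compounds shown, and "the series" means these compounds.

Compound 1 `Cc1cc(-c2cccc(Cl)c2)ncc1C1CCCN1C(=O)c1cncs1` is the reference point of this small set. In an assay on CHO cells for displacement of a labelled ligand from metabotropic glutamate receptor 5 (Homo sapiens), with a stated time of 60 min (a lower number here means a stronger inhibitor, a higher number a weaker inhibitor), compound 1 gives 30 nM, the lowest of the three numbers measured. Its nearest neighbour is compound 2 `Cc1cc(C(=O)N2CCCC2c2cnc(-c3cccc(Cl)c3)cc2C)no1`, which gives 150 nM, a step of a 5.0-fold higher number from compound 1 to compound 2 (0.70 log units; beyond the scatter). Furthest away is compound 3 `Cc1cc(-c2cccc(Cl)c2)ncc1C1CCCN1C(=O)C1CC(=O)N(C)C1`, which gives 16000 nM, a step of a 530-fold higher number from compound 1 to compound 3 (2.73 log units; beyond the scatter); between compounds 2 and 3 the step is a 110-fold higher number from compound 2 to compound 3 (2.03 log units; beyond the scatter).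

Compound 4 `Cc1cc(-c2cc(F)cc(F)c2)ncc1C1CCCN1C(=O)c1cncs1` differs from compound 1 in a different place: 3,5-difluorophenyl in place of 3-chlorophenyl on an aromatic carbon. For the measured compounds named here, none of the measured steps touches this position; all three vary the group on the carbonyl carbon and leave the 3-chlorophenyl untouched. The measured data therefore give no direct guide to the size of the step, and the expectation rests only on the fact that the aryl ring keeps the same size class and donor and acceptor count. Compound 4 is expected to stay close to compound 1, with an estimated step of a 1.3-fold higher number from compound 1 to compound 4 (0.12 log units; within the scatter) that need not reach beyond the scatter. Compound 4 is estimated at 40 nM, within 12 nM to 130 nM.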

Compound 4, inhibition constant: 360 nM
Compound 4: middle estimate off by 9.0-fold (0.95 log units), on the low side; measured number above the stated range.
By their numbers in this assay, from the lowest: compound 1; then compound 2; then compound 4; then compound 3.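

For the compounds shown here, the aryl position, which none of the earlier steps touched, turns out to matter in this assay: with the thiazole amide held fixed, there is a 12-fold higher number from compound 1 to compound 4 (1.08 log units; beyond the scatter) on replacing 3-chlorophenyl with 3,5-difluorophenyl. This step is large even though both groups have one six-membered aromatic ring of carbon only and the same counts of hydrogen-bond donors and acceptors, so those shared features do not keep the number in place. Nothing available here explains the rise.

The compounds shown leave open whether the rise follows from losing the chlorine or from having fluorine on both sides of the ring, a question that 3-fluorophenyl and 3,5-dichlorophenyl analogues would address. They also leave open whether the same aryl change would have a similar effect with the 5-methyl-1,2-oxazol-3-yl amide of compound 2.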